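The source may hold more compounds than are shown below. What is called first, only, known or untested is meant among the compounds shown, and "the series" means these compounds.

Series notes. Compound 2 `CCCC/C(C)=N\Nc1nc(-c2cccc([N+](=O)[O-])c2)cs1` gives 1460000 nM in a functional assay, with a stated time of 90 min; on this read-out higher numbers stand for an effect only at larger amounts of compound and lower numbers for an effect already at smaller amounts; compound 1 `CC(C)=NNc1nc(-c2cccc([N+](=O)[O-])c2)cs1` gives 1750000 nM in this assay, and the pair lie within the scatter of each other, as the step of a 1.2-fold lower number from compound 1 to compound 2 (0.08 log units; within the scatter) shows. Compound 3 `CCCCCC/C(C)=N\Nc1nc(-c2cccc([N+](=O)[O-])c2)cs1` differs from compound 2 by ethyl in place of hydrogen on a saturated chain carbon, four bonds along the chain from a carbon with a double bond to nitrogen. Among the measured compounds shown here, the only step that bears on this change is the chain lengthening from compound 1 to compound 2, which stayed within the scatter, so for compound 3 no step beyond the scatter is expected in this assay, estimated as a 1.2-fold lower number from compound 2 to compound 3 (0.09 log units; within the scatter). Compound 3 is therefore estimated at 1200000 nM, expected range 500000 nM to 3000000 nM.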

Compound 3, half-maximal effective concentration: 1240000 nM
Beside the measured number, compound 3's estimate is 1.0-fold (0.01 log units) below it, within the range that was stated.
By their numbers in this assay, from the lowest: compounds 3, 2 and 1 (each within the scatter of the next).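

In this assay, ethyl in place of hydrogen on a saturated chain carbon, four bonds along the chain from a carbon with a double bond to nitrogen, gives a 1.2-fold lower number from compound 2 to compound 3 (0.07 log units; within the scatter) and stays within the scatter. Taken across the whole chain, pentyl in place of hydrogen gives a 1.4-fold lower number from compound 1 to compound 3 (0.15 log units; within the scatter), so even the largest change shown here does not leave the scatter. No supporting measurement bears on this result.
On these data alone, whether a longer chain, a branched chain, or an amine or carboxylic acid at the chain end would give a step beyond the scatter remains open. The compounds shown also leave open how changes elsewhere on the shared core would read in this assay.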